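A fluoro step at the assay limit

This account rests on a few compounds, and the source may have more. Where it says the series, first, only, none or still open, it means among the compounds named here.

Of the compounds shown here, three have been measured in a functional assay on A-375 cells (Homo sapiens) for cytotoxicity, read by CCK-8 assay, with a stated time of 24 h; a higher number here means a weaker inhibitor, a lower number a stronger inhibitor. Among the measured compounds shown here, compound 1 `COc1ccccc1Oc1c(N)nc(-c2ccccc2)nc1Cl` gives 7220 nM, the only exact number so far. Compound 2 `COc1ccc(-c2nc(N)c(Oc3ccccc3OC)c(Cl)n2)cc1` reaches only a limit, > 80000 nM. Compound 3 `COc1ccccc1Oc1c(N)nc(-c2ccccc2)nc1OCCO` also reaches only a limit, > 80000 nM. Compound 3 therefore has no exact place on the scale and shares the limit of > 80000 nM in this assay, at which 2 of the 3 values shown sit, with one other compound.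

Compound 4 `COc1ccccc1Oc1c(N)nc(-c2ccccc2F)nc1OCCO` carries fluoro in place of hydrogen on an aromatic carbon, ortho to a large group, so that phenyl becomes 2-fluorophenyl: fluoro in place of hydrogen on an aromatic carbon. For the measured compounds named here, no measured step tests fluoro itself. Going by the values given here, the nearest precedent is methoxy in place of hydrogen on an aromatic carbon, which gave an at least 11-fold higher number from compound 1 to compound 2 (1.04 log units; beyond the scatter), a large step beyond the scatter. The other relevant change, 2-hydroxyethoxy in place of chloro, gave an at least 11-fold higher number from compound 1 to compound 3 (1.04 log units; beyond the scatter), also large, and compound 4 keeps that 2-hydroxyethoxy group. From the compounds shown here alone, neither step suggests a large gain, so no step beyond the scatter is expected, though the direction remains open. The expected change is an at least 1.3-fold lower number from compound 3 to compound 4 (0.12 log units; that floor lies within the scatter). For compound 4 the estimated value is 60000 nM, with an expected range from 20000 nM to 120000 nM.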

Compound 4, half-maximal inhibitory concentration: > 80000 nM
Compound 4 gave a limit, no number (the forecaster's own chance of this, stated with the estimate: 65%); middle value at least 1.3-fold (0.12 log units) from the limit.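

Compound 3 and compound 4 both stand at a limit in this assay rather than at a number, so the step between them, fluoro in place of hydrogen on an aromatic carbon, cannot be read: the limit of > 80000 nM in this assay, at which 3 of the 4 values shown sit.

The compounds shown leave open whether this fluoro changes the read-out at all, in either direction, with compound 1 alone holding an exact number.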